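A few compounds are considered here, and "the series" means these few. Any claim that something is new, unique, unknown or untested is made for them only; others in the source may bear on it.

Measured values in a functional assay on B16-F0 cells (Mus musculus) for inhibition, read by CCK-8 assay, with a stated time of 48 h (on this read-out higher numbers stand for weaker inhibition and lower numbers for stronger inhibition), are as follows
- compound 1 `COc1cc(-c2ccnc3cc(-c4ccc(C)cc4)nn23)cc(OC)c1OC` gives 21 nM
- compound 2 `COc1cc(-c2ccnc3cc(-c4cn(C)c5ccccc45)nn23)cc(OC)c1OC` gives 185 nM
- compound 3 `COc1cc(-c2ccnc3cc(-c4cn(C(=O)OC(C)(C)C)c5ccccc45)nn23)cc(OC)c1OC` gives 3070 nM

Compound 2 sits between the other two numbers, with compound 1 lower and compound 3 higher. Compound 4 `COc1ccc(-c2cc3nccc(-c4cc(OC)c(OC)c(OC)c4)n3n2)cc1F` differs from it by one swap on the shared core: 3-fluoro-4-methoxyphenyl in place of 1-methyl-1H-indol-3-yl on an aromatic carbon. The most relevant evidence is an 8.8-fold higher number from compound 1 to compound 2 (0.94 log units; beyond the scatter), a modest step that came with replacing 4-methylphenyl by 1-methyl-1H-indol-3-yl. Compound 4 makes the opposite kind of swap, restoring a substituted phenyl, though not the same one. The large 17-fold higher number from compound 2 to compound 3 (1.22 log units; beyond the scatter) concerns a nitrogen group that compound 4 does not carry, so it bears little here. A modest step to a lower number is therefore expected in this assay, namely a 4.1-fold lower number from compound 2 to compound 4 (0.61 log units; beyond the scatter) as an estimate. For compound 4 the estimated value is 45 nM, within an expected range of 12 nM to 170 nM.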

Compound 4, half-maximal inhibitory concentration: 3950 nM
The estimate for compound 4 lay 88-fold (1.94 log units) below the measured number; the whole stated range lies below it.
By their numbers in this assay, from the lowest: compound 1; then compound 2; then compounds 3 and 4 (each within the scatter of the next).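

At this aromatic carbon of the shared core, a phenyl ring does not by itself give strong inhibition in this assay: placing 3-fluoro-4-methoxyphenyl here gives a 21-fold higher number from compound 2 to compound 4 (1.33 log units; beyond the scatter), and comparison with the other phenyl compound gives a 190-fold higher number from compound 1 to compound 4 (2.27 log units; beyond the scatter). What the phenyl ring carries can therefore matter more here than the choice between phenyl and 1-methyl-1H-indol-3-yl. No measurement shown explains this drop in inhibition. Going by these compounds, it remains open whether the fluoro or the methoxy group accounts for the change, and how an amine or a carboxylic acid on this phenyl ring would read.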